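The compounds below may be only part of what the source reports. "The series", "measured", "known", "first", "only" and "open" are said of these compounds alone.

Measured so far in a functional assay on the whole organism with Rattus norvegicus as the target, at a dose of 25 mg/kg by the intravenous route; on this read-out higher numbers stand for an effect only at larger amounts of compound and lower numbers for an effect already at smaller amounts:

- Compound 1 `CCCCc1ccc(C(=O)Nc2cc(C(=O)O)cc(C(=O)O)c2)cc1`: 12.3 mg/kg
- Compound 2 `O=C(O)c1cc(NC(=O)c2ccc([N+](=O)[O-])cc2)cc(C(=O)O)c1`: 9.8 mg/kg
- Compound 3 `O=C(Nc1cccc(-c2nn[nH]n2)c1)c1cccc(-c2nn[nH]n2)c1`: 1.6 mg/kg

Compound 2, at 9.8 mg/kg, lies within the usual scatter of compound 1. Compound 3 gives a lower number than compound 2, and that gap goes beyond the scatter.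

The next compound to be tested is compound 4 `O=C(O)c1cc(NC(=O)c2ccc(-c3nn[nH]n3)cc2)cc(C(=O)O)c1`. It keeps the core of compound 2 and alters a single group, on an aromatic carbon para to a large group: 2H-tetrazol-5-yl in place of nitro on an aromatic carbon. Put simply, 2H-tetrazol-5-yl takes the place of nitro.

Going by the values given here, only one measured step involves this same place: a 1.3-fold lower number from compound 1 to compound 2 (0.10 log units; within the scatter). That exchange of nitro for butyl stayed within the scatter, so a swap at this place has so far shown little effect. Compound 3, at 1.6 mg/kg, also carries 2H-tetrazol-5-yl groups, which hints at a lower number. However, it differs from compound 2 in more than one place, so its value cannot be credited to that group alone.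

In this assay, the expected change is therefore small and towards a lower number, and it is not clearly beyond the scatter: a 1.8-fold lower number from compound 2 to compound 4 (0.25 log units; within the scatter). Compound 4 is estimated at 5.5 mg/kg, with an expected range of 1.8 mg/kg to 14 mg/kg.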

Compound 4, dose for 50% inhibition: 1.2 mg/kg
Estimate against measurement, compound 4: 4.6-fold (0.66 log units) above, outside the stated range (below it).
By their numbers in this assay, from the lowest: compounds 4 and 3 (each within the scatter of the next); then compounds 2 and 1 (each within the scatter of the next).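

The earlier exchange at this aromatic carbon suggested a place that hardly cares what it carries in this assay, with a 1.3-fold lower number from compound 1 to compound 2 (0.10 log units; within the scatter). Putting 2H-tetrazol-5-yl there overturns that reading, giving an 8.2-fold lower number from compound 2 to compound 4 (0.91 log units; beyond the scatter) and a 10-fold lower number from compound 1 to compound 4 (1.01 log units; beyond the scatter), so with the rest of the molecule unchanged, the group at this one place can strongly shift the dose needed. Butyl and nitro remain within the scatter of each other, while the five-membered aromatic ring with 4 hetero atoms stands apart from both, which shows that the place does not respond to every change but does respond to this one.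

Nothing measured here indicates which feature of the new group lies behind the shift. From the compounds shown here alone, it remains open whether a carboxylic acid, an amine or a longer chain at this same carbon would also give a number as low as that of compound 4, and whether a five-membered aromatic ring with fewer nitrogen atoms, such as an imidazole, would do the same.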